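Methyl to fluoro on a sulfonamide phenyl ring

The compounds below may be only part of what the source reports. "The series", "measured", "known", "first", "only" and "open" are said of these compounds alone.

Measured compounds:
compound 1, `Cc1ccc(S(=O)(=O)NCc2cn(C[C@H](O)[C@H]3OC(=O)C(OCc4ccccc4)=C3OCc3ccccc3)nn2)cc1`, gives 50 nM in an ADME assay on HFF cells (Homo sapiens) for cytotoxicity, read by MTT assay, with a stated time of 72 h; on this read-out higher numbers stand for weaker inhibition and lower numbers for stronger inhibition
compound 2, `O=C1O/C(=C\Cn2cc(-c3cc(F)cc(F)c3)nn2)C(OCc2ccccc2)=C1OCc1ccccc1`, gives > 100000 nM, a limit of the assay
compound 3, `Cc1ccc(-c2cn(C/C=C3\OC(=O)C(OCc4ccccc4)=C3OCc3ccccc3)nn2)cc1`, gives > 100000 nM, a limit of the assay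

Compound 1 is the only one of the three that gives a number in this assay; the other two sit at a limit, (the limit of > 100000 nM in this assay, at which 2 of the 3 values shown sit). Going by the values given here, the single step between measured compounds, a step that the two limits leave unreadable from compound 2 to compound 3, runs between two limits and so cannot be read.

Compound 4, `O=C1O[C@H]([C@@H](O)Cn2cc(CNS(=O)(=O)c3ccc(F)cc3)nn2)C(OCc2ccccc2)=C1OCc1ccccc1`, has not yet been measured. It differs from compound 1 by fluoro in place of methyl on an aromatic carbon. No measured step bears directly on this change: the only step shown alters a different aryl group and is itself unreadable. With nothing pointing either way, the expectation is no shift beyond the usual scatter.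

Compound 4 is therefore expected to give about 60 nM in this assay, with a range from 15 nM to 250 nM. The expected step is a 1.2-fold higher number from compound 1 to compound 4 (0.08 log units; within the scatter), that is, none beyond the scatter.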

Compound 4, half-maximal inhibitory concentration: 30 nM
Beside the measured number, compound 4's estimate is 2.0-fold (0.30 log units) above it, and the stated range covers the measured number.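

In this assay, putting fluoro in place of methyl on the aromatic carbon para to a large group gives a 1.7-fold lower number from compound 1 to compound 4 (0.22 log units; within the scatter). This is the first readable step among the compounds shown, as the only earlier step ran between two limits and could not be read, and it shows that this swap at this position leaves the number within the usual scatter of repeated measurements. Nothing available here gives a reason for this result, and with a step this small there is no shift to explain.

The compounds shown hold only methyl and fluoro at this position, so how an amine, a carboxylic acid or a longer chain such as propyl would read there remains open. Also open, on these data alone, is whether the same swap would read alike on a core other than that of compound 1.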